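The source may hold more compounds than are shown below. What is called first, only, known or untested is meant among the compounds shown, and "the series" means these compounds.

Three compounds share one core and are compared in a functional assay on CHO cells for antagonist activity at prostaglandin E2 receptor EP3 subtype (Homo sapiens), read by cAMP accumulation, with a stated time of 30 min; on this read-out lower numbers stand for stronger inhibition and higher numbers for weaker inhibition. Compound 1 `CC(C)C(c1ccc(-c2ccc3cccc(F)c3c2)[nH]c1=O)C1NC(=O)NC1=O` gives 320 nM, the highest of the three numbers. Compound 2 `CCC(CC)C(/C=C1\OC(=O)NC1=O)c1ccc(-c2ccc3cccc(F)c3c2)[nH]c1=O` gives 23 nM, and compound 3 `CC(C)[C@H](C[C@H]1OC(=O)NC1=O)c1ccc(-c2ccc3cccc(F)c3c2)[nH]c1=O` gives 15 nM; both lie well beyond the scatter from compound 1, with compound 3 the furthest from it.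

The change from compound 1 to compound 4 `CC(C)C(CC1NC(=O)NC1=O)c1ccc(-c2ccc3cccc(F)c3c2)[nH]c1=O` is small: (2,5-dioxoimidazolidin-4-yl)methyl in place of 2,5-dioxoimidazolidin-4-yl on a saturated chain carbon bound to an aromatic carbon and a saturated chain carbon. The ring itself stays; only a single-carbon link is inserted. Compound 3, which also carries its ring through a one-carbon link, stands far below compound 1, so a drop in this assay is expected for compound 4, of roughly the size a 9.1-fold lower number from compound 1 to compound 4 (0.96 log units; beyond the scatter). Compound 4 is estimated at 35 nM, with a likely range from 10 nM to 120 nM.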

Compound 4, half-maximal inhibitory concentration: 31 nM
Beside the measured number, compound 4's estimate is 1.1-fold (0.05 log units) above it, and the stated range covers the measured number.
By their numbers in this assay, from the lowest: compounds 3, 2 and 4 (each within the scatter of the next, the first and the last beyond it); then compound 1.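

In this assay the swap of 2,5-dioxoimidazolidin-4-yl for (2,5-dioxoimidazolidin-4-yl)methyl gives a 10-fold lower number from compound 1 to compound 4 (1.01 log units; beyond the scatter), on a saturated chain carbon bound to an aromatic carbon and a saturated chain carbon. This is the first pair shown that differs in one place, and it shows that a single added carbon can alter the result greatly while the ring stays the same. No measurement shown explains this gain. As far as these compounds go, whether a longer chain would change the number further remains open, as does whether an amine or a carboxylic acid could replace the ring on the same one-carbon link.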